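From 4-Fluorophenyl to 3,5-Difluorophenyl

The source may report more compounds than this note shows. Statements on the series, on what has been measured and on what is new or still open speak of the compounds shown alone.

In a functional assay on the whole organism for inhibition, with Lemna aequinoctialis as the target, with a stated time of 7 days, tested at 5 ug/mL (on this read-out higher numbers stand for more inhibition of growth at the one concentration tested and lower numbers for less inhibition of growth), compound 1 (`O=C1Nc2ccc(F)cc2/C1=N/NC(=S)Nc1ccccc1F`) gives 20%, and compound 2 (`O=C1Nc2ccc(F)cc2/C1=N/NC(=S)Nc1ccc(F)cc1`) gives 10%. These two numbers lie within the scatter of each other, so the data cannot tell the two compounds apart. Compound 3 (`O=C1Nc2ccc(F)cc2/C1=N/NC(=S)Nc1cc(F)cc(F)c1`) keeps the shared core and differs from compound 2 in one group: 3,5-difluorophenyl in place of 4-fluorophenyl on an amide-type nitrogen. Within the data shown here, the only measured step that bears on this change is the exchange of 2-fluorophenyl for 4-fluorophenyl, which gave a number 10 percentage points lower from compound 1 to compound 2 (within the scatter). Among the measured compounds shown here, no measured compound carries 3,5-difluorophenyl, so the evidence is thin, and no step beyond the scatter is expected in this assay. The estimated change is a number 5 percentage points higher from compound 2 to compound 3 (within the scatter), a small one. For compound 3 the expected value is 15%, with an estimated range of 0% to 35%.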

Compound 3, percent growth inhibition at one concentration: 0%
For compound 3 the middle estimate is 15 percentage points above the measured one; low and high end bracket the measured number.
By their numbers in this assay, from the lowest: compounds 3, 2 and 1 (each within the scatter of the next, the first and the last beyond it).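

In this assay, 3,5-difluorophenyl in place of 4-fluorophenyl on the amide-type nitrogen gives a number 10 percentage points lower from compound 2 to compound 3 (within the scatter) and so cannot be told apart from the scatter. Set against 2-fluorophenyl, the same group gives a number 20 percentage points lower from compound 1 to compound 3 (beyond the scatter) and thus provides the first step at this position that the data can resolve, showing that the fluorophenyl group carried here can shift growth inhibition, though only modestly. No supporting data are available to explain this difference.

All three compounds carry a fluorinated phenyl group on this nitrogen, so the compounds shown leave open how an unsubstituted phenyl, a methoxyphenyl or a simple alkyl chain would behave there. They also leave open whether a carboxylic acid or an amine on that ring would raise growth inhibition in this assay at all.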